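Compound 3: shortening the acyl group at the limit

A few compounds are considered here, and "the series" means these few. Any claim that something is new, unique, unknown or untested is made for them only; others in the source may bear on it.

Measured in a toxicity assay on THP-1 cells (Homo sapiens) for inhibition; on this read-out lower numbers stand for higher toxicity in this test and higher numbers for lower toxicity in this test
compound 1 `COc1ccc(-c2cnc(NC(=O)c3ccccc3O)n2C)cc1` gives > 100000 nM as a limit of the assay
compound 2 `COc1ccc(-c2cnc(NC(=O)c3ccccc3)n2C)cc1` gives > 100000 nM as a limit of the assay

In this assay compound 2 stands only at a limit, > 100000 nM, and has no number. Going by the values given here, the series so far shows (the limit of > 100000 nM in this assay, at which 2 of the 2 values shown sit).

Compound 3 `COc1ccc(-c2cnc(NC(C)=O)n2C)cc1` carries methyl in place of phenyl on a carbonyl carbon.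

Among the compounds with values here, the one measured step is a step that the two limits leave unreadable from compound 1 to compound 2, with hydrogen in place of hydroxy on an aromatic carbon. Within the data shown here, it gives no size to carry over, and no measured step concerns the phenyl.

Compound 2 sits at the limit > 100000 nM, and on that ground no step beyond the scatter and no direction is expected in this assay. The estimated step is a number no higher from compound 2 to compound 3 (the limit leaves the size open).

The value expected for compound 3 is about 100000 nM, with an estimated range from 50000 nM to 200000 nM, and a report as a limit again is the likeliest outcome.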

Compound 3, half-maximal cytotoxic concentration: > 100000 nM
Compound 3: no number, only a limit; the forecaster's own chance of this, stated with the estimate: 85%; the middle value lies on the limit itself.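

In this assay no step can be read among compound 1, compound 2 and compound 3, which share one limit: the limit of > 100000 nM in this assay, at which 3 of the 3 values shown sit.

The compounds shown leave open how far toxicity in this assay responds to the hydroxy on the aromatic carbon, or to phenyl or methyl on the carbonyl carbon, since none of the three has a number.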